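The source may hold more compounds than are shown below. What is called first, only, known or untested is meant among the compounds shown, and "the series" means these compounds.

Measured in a functional assay on L1210 cells (Mus musculus); a lower number here means a stronger inhibitor, a higher number a weaker inhibitor:
- Compound 1 `COC[C@H]1OC(n2c(Cl)nc3cc(Cl)c(Cl)cc32)[C@H](O)[C@@H]1O`: 60000 nM
- Compound 2 `O[C@@H]1[C@@H](CF)OC(n2c(Cl)nc3cc(Cl)c(Cl)cc32)[C@@H]1O`: > 100000 nM

Compound 2 has only a limit, not a number: it stands at the limit of > 100000 nM in this assay, at which 1 of the 2 values shown sits. Compound 3 `O[C@@H]1[C@@H](CCl)OC(n2c(Cl)nc3cc(Cl)c(Cl)cc32)[C@@H]1O` differs from it by chloro in place of fluoro on a saturated chain carbon bound to a saturated ring carbon. For the measured compounds named here, the one measured step at that carbon is an at least 1.6-fold higher number from compound 1 to compound 2 (0.22 log units; that floor lies within the scatter). With so little to go on, no step beyond the scatter is expected in this assay. The estimated step is an at least 1.2-fold lower number from compound 2 to compound 3 (0.09 log units; that floor lies within the scatter). Compound 3 is expected near 80000 nM, with an estimated range of 30000 nM to 150000 nM.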

Compound 3, half-maximal inhibitory concentration: > 100000 nM
Compound 3 ended at the assay's limit; the forecaster's own chance of this, stated with the estimate: 45%; middle value at least 1.2-fold (0.09 log units) away from the limit.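

In this assay, chloro in place of methoxy gives an at least 1.6-fold higher number from compound 1 to compound 3 (0.22 log units; that floor lies within the scatter), so a second halogen also fails to give a readable improvement on compound 1. Compound 2 and compound 3 both carry limits rather than numbers, so the step between them cannot be read and fluoro and chloro cannot be ranked. With compound 3, the limit now holds for both halogen compounds: the limit of > 100000 nM in this assay, at which 2 of the 3 values shown sit.

Going by these compounds, whether an amine or a longer ether such as ethoxy on this carbon would give a measurable value remains open. So does whether any group here could clearly outperform methoxy.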